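The compounds below may be only part of what the source reports. "The series", "measured", "known", "first", "only" and "open" are said of these compounds alone.

Measured so far in a functional assay on MDA-MB-453 cells (Homo sapiens) for cytotoxicity, read by MTT assay, with a stated time of 72 h; a higher number here means a weaker inhibitor, a lower number a stronger inhibitor:
compound 1 `O=C(Nc1ccc(Cl)c(C(=O)Nc2ccc(-c3ncc[nH]3)nc2)c1)c1ccc(Cl)c(Cl)c1`, 11400 nM;
compound 2 `Cc1cc(C(=O)Nc2ccc(Cl)c(C(=O)Nc3ccc(-c4ncc[nH]4)nc3)c2)ccc1Cl`, 8760 nM.

Compound 3 `Cc1ccc(NC(=O)c2ccc(Cl)c(C(F)(F)F)c2)cc1C(=O)Nc1ccc(-c2ncc[nH]2)nc1` belongs to the same family, but in this assay compound 3 gives "not determined" (no result reported), so it cannot be placed among these numbers. Compound 4 `O=C(Nc1ccc(Cl)c(C(=O)Nc2ccc(-c3ncc[nH]3)nc2)c1)c1ccc(Cl)c(C(F)(F)F)c1` differs from compound 3 by chloro in place of methyl on an aromatic carbon. Within the data shown here, the one measured step that bears on this exchange runs the other way: a 1.3-fold lower number from compound 1 to compound 2 (0.11 log units; within the scatter), a step that stayed within the scatter. The same swap in reverse is therefore expected to move this assay by no more than the scatter, in no clear direction, and compound 4 carries the same chloro as compound 1 on that ring. Compound 4 is thus expected near 10000 nM, within 3000 nM to 30000 nM, because a 1.3-fold lower number from compound 1 to compound 2 (0.11 log units; within the scatter) was so small.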

Compound 4, half-maximal inhibitory concentration: 8350 nM
Compound 4: the middle estimate sits 1.2-fold (0.08 log units) above what was measured; low and high end bracket the measured number.
By their numbers in this assay, from the lowest: compounds 4, 2 and 1 (each within the scatter of the next).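

Trifluoromethyl now joins chloro and methyl on the same aromatic carbon, and in this assay the two new steps stay small (a 1.0-fold lower number from compound 2 to compound 4 (0.02 log units; within the scatter); a 1.4-fold lower number from compound 1 to compound 4 (0.14 log units; within the scatter)). Among these compounds, the three groups thus give values that cannot be told apart, which the single earlier exchange of chloro for methyl could not show. Nothing measured here offers an explanation for this.

From the compounds shown here alone, an amine or a carboxylic acid on that carbon remains open. Compound 3 has no number, so the exchange of methyl for chloro that leads to compound 4 cannot be read.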